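The compounds below may be only part of what the source reports. "The series", "measured", "known", "first", "only" and "open" are said of these compounds alone.

In a functional assay for inhibition, with Homo sapiens as the target (a higher number here means a weaker inhibitor, a lower number a stronger inhibitor), compound 2 `c1cc(Nc2nccc(-c3cccnc3)n2)cc(OCCn2ccnc2)c1` gives 100 nM and compound 3 `c1cc(Nc2nccc(-c3cccs3)n2)cc(OCCn2ccnc2)c1` gives 100 nM, together the lowest of the three numbers, while compound 1 `CN(C)c1cccc(Nc2nccc(-c3cccnc3)n2)c1` gives 1800 nM. Compound 4 `CC1CCN(c2cccc(Nc3nccc(-c4cccnc4)n3)c2)CC1` carries 4-methylpiperidin-1-yl in place of 2-(1H-imidazol-1-yl)ethoxy on an aromatic carbon. Among the measured compounds shown here, the closest precedent is the large step of an 18-fold lower number from compound 1 to compound 2 (1.26 log units; beyond the scatter), where 2-(1H-imidazol-1-yl)ethoxy replaced dimethylamino, and compound 4 gives up that same group. The other step, no change at the digits printed from compound 2 to compound 3 (within the scatter), concerns a different place and says little here. In this assay a large rise in the number is therefore expected, with an estimated step of a 10-fold higher number from compound 2 to compound 4 (1.00 log units; beyond the scatter). Compound 4 is estimated at 1000 nM, within an expected range of 250 nM to 4000 nM.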

Compound 4, half-maximal inhibitory concentration: 1200 nM
Estimate against measurement, compound 4: 1.2-fold (0.08 log units) below; the measured number falls inside the stated range.
By their numbers in this assay, from the lowest: compounds 2 and 3 (each within the scatter of the next); then compounds 4 and 1 (each within the scatter of the next).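

In this assay the change brings a 12-fold higher number from compound 2 to compound 4 (1.08 log units; beyond the scatter) and so shows that the low number at this aromatic carbon is not lost with dimethylamino alone. A second replacement for 2-(1H-imidazol-1-yl)ethoxy, carrying a non-aromatic ring, also ends far from it, while a 1.5-fold lower number from compound 1 to compound 4 (0.18 log units; within the scatter) leaves 4-methylpiperidin-1-yl and dimethylamino indistinguishable in this assay. Nothing available explains this difference between the groups. Going by these compounds, whether the imidazole ring or the ethoxy chain carries the gain stays open, as does the standing of a morpholine or a longer chain ending in an amine here.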